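The source may report more compounds than this note shows. Statements on the series, on what has been measured and on what is new or still open speak of the compounds shown alone.

Three compounds have been measured in a functional assay on A549 cells (Homo sapiens) for cytotoxicity, read by MTT assay, with a stated time of 72 h; on this read-out higher numbers stand for weaker inhibition and lower numbers for stronger inhibition:

Compound 1 `CCN(CC)CCCOc1c(OCc2ccccc2)cc(O)c2c(=O)cc(-c3ccccc3)oc12` gives 3620 nM.
Compound 2 `O=c1cc(-c2ccccc2)oc2c(OCCCN3CCCC3)c(OCc3ccccc3)cc(O)c12` gives 4720 nM.
Compound 3 `CN(C)CCCCOc1c(OCc2ccccc2)cc(O)c2c(=O)cc(-c3ccccc3)oc12` gives 1090 nM.

Compound 3 stands at the lowest number of the three: a 3.3-fold lower number from compound 1 to compound 3 (0.52 log units; beyond the scatter) and a 4.3-fold lower number from compound 2 to compound 3 (0.64 log units; beyond the scatter). Both of those steps alter the amine and the chain length together, so neither isolates the amine alone. Compound 4 `O=c1cc(-c2ccccc2)oc2c(OCCCCN3CCCC3)c(OCc3ccccc3)cc(O)c12` keeps the chain of compound 3 and changes only the amine: pyrrolidin-1-yl in place of dimethylamino on a saturated chain carbon, four bonds along the chain from an oxygen on an aromatic ring. For the measured compounds named here, the one measured step that exchanges an open-chain amine for a ring amine without touching the chain is a 1.3-fold higher number from compound 1 to compound 2 (0.12 log units; within the scatter), a difference too small to count as a real change. On that basis the step of a 1.4-fold higher number from compound 3 to compound 4 (0.14 log units; within the scatter) is expected to remain small, leaning if anything toward a slightly higher number, much as seen from compound 1 to compound 2. In this assay compound 4 is therefore estimated at 1500 nM, with a likely range from 700 nM to 3500 nM.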

Compound 4, half-maximal inhibitory concentration: 1100 nM
Compound 4: middle estimate off by 1.4-fold (0.13 log units), on the high side, and the stated range covers the measured number.
By their numbers in this assay, from the lowest: compounds 3 and 4 (each within the scatter of the next); then compounds 1 and 2 (each within the scatter of the next).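

In this assay, the step of a 1.0-fold higher number from compound 3 to compound 4 (0.00 log units; within the scatter) shows that on the longer chain, pyrrolidin-1-yl and dimethylamino cannot be told apart. With the amine held fixed, the step of a 4.3-fold lower number from compound 2 to compound 4 (0.63 log units; beyond the scatter) isolates the chain for the first time, and the step of a 3.3-fold lower number from compound 1 to compound 4 (0.52 log units; beyond the scatter), which changes the amine and the chain together, is of similar size, so among these compounds the longer chain, not the choice of amine, goes with the lower number. Nothing measured here explains this difference.

As far as these compounds go, it remains open whether a chain longer still would lower the number further or reverse the trend. It is also unknown whether a six-membered ring amine, such as piperidin-1-yl or morpholin-4-yl, would match pyrrolidin-1-yl on the longer chain.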